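Swapping the aryl-thioether for a pyrrolidine on the core

The source may hold more compounds than are shown below. What is called first, only, known or untested is meant among the compounds shown, and "the series" means these compounds.

Measured compounds so far:
- compound 1, `Cc1cc(-c2cc(Cl)cc(Cl)c2)c(S(C)(=O)=O)cc1C(=O)N=C(N)N`: 130 nM
- compound 2, `Cc1cc(Sc2ccncc2)c(S(C)(=O)=O)cc1C(=O)N=C(N)N`: 13 nM

Both values come from a functional assay for inhibition of sodium/hydrogen exchanger (Oryctolagus cuniculus); on this read-out higher numbers stand for weaker inhibition and lower numbers for stronger inhibition. Within the data shown here, compound 2 stands at the lowest of the two numbers, and the single known step, a 10-fold lower number from compound 1 to compound 2 (1.00 log units; beyond the scatter), shows that changing the group on this aromatic carbon can shift the read-out well beyond the scatter.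

Compound 3, `Cc1cc(N2CCCC2)c(S(C)(=O)=O)cc1C(=O)N=C(N)N`, differs from compound 2 in that same place: pyrrolidin-1-yl in place of (pyridin-4-yl)sulfanyl on an aromatic carbon. Among the measured compounds shown here, no measured step involves pyrrolidin-1-yl, so the direction of the change is not given by the data; the step from compound 1 to compound 2 only shows that this position is sensitive. With that uncertainty, compound 3 is expected to land close to compound 2, perhaps slightly weaker, an expected step of a 2.3-fold higher number from compound 2 to compound 3 (0.36 log units; beyond the scatter). The estimate for compound 3 in this assay is 30 nM, with a range from 8 nM to 120 nM.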

Compound 3, half-maximal inhibitory concentration: 11 nM
Compound 3: middle estimate off by 2.7-fold (0.44 log units), on the high side, and the stated range covers the measured number.
By their numbers in this assay, from the lowest: compounds 3 and 2 (each within the scatter of the next); then compound 1.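

In this assay, the swap at this position, ortho to a methylsulfonyl group, gives a 1.2-fold lower number from compound 2 to compound 3 (0.07 log units; within the scatter), so pyrrolidin-1-yl and (pyridin-4-yl)sulfanyl cannot be told apart here. This position therefore tolerates two quite different groups: a five-membered non-aromatic ring attached through its nitrogen, and a six-membered aromatic ring attached through sulfur. Compared with the 3,5-dichlorophenyl group, the change gives a 12-fold lower number from compound 1 to compound 3 (1.07 log units; beyond the scatter), so compound 1 remains the outlier among the three, and no measurement given here explains these numbers.

On these data alone, it remains open whether an open-chain amine such as dimethylamino, or a ring with a second hetero atom such as morpholine, would match compound 3. A plain phenyl ring would help show whether the gap to compound 1 follows its two chlorine atoms or its directly attached ring.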